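Acetamido to benzamido on the saturated ring: hepatocyte stability

This account rests on a few compounds, and the source may have more. Where it says the series, first, only, none or still open, it means among the compounds named here.

Measured compounds:
compound 1 `CC(=O)NC1CCC(CN2CCN(c3cc(=O)c4cc(C(F)(F)F)cc([N+](=O)[O-])c4s3)CC2)CC1` — > 1.55 h
compound 2 `O=C(OC1CCC(CN2CCN(c3cc(=O)c4cc(C(F)(F)F)cc([N+](=O)[O-])c4s3)CC2)CC1)c1cccs1` — 0.0917 h

In an ADME assay on cells (Hepatocyte, Homo sapiens) for metabolic stability (on this read-out higher numbers stand for a longer-lived compound and lower numbers for a shorter-lived compound), compound 1 gives > 1.55 h, which is a limit of the assay and not a number; compound 1 therefore stands at the limit of > 1.55 h in this assay, at which 1 of the 2 values shown sits. In this assay, among the measured compounds shown here, compound 2 gives 0.0917 h, the only actual number in the set.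

For the measured compounds named here, the single measured step, an at least 16-fold lower number from compound 1 to compound 2 (1.22 log units; beyond the scatter), runs from the acetamido compound to the ester compound. Compound 3 `O=C(NC1CCC(CN2CCN(c3cc(=O)c4cc(C(F)(F)F)cc([N+](=O)[O-])c4s3)CC2)CC1)c1ccccc1` reverses that kind of change: benzamido in place of ((thiophen-2-yl)carbonyl)oxy on a saturated ring carbon. Compound 3 thus carries an amido attachment, as compound 1 does, while keeping an aromatic ring on the carbonyl, as compound 2 does. Going by the values given here, the step from compound 1 to compound 2 is the only guide, and it points to a rise when the amido attachment returns, though the phenyl ring is a new element without a measured counterpart.

Compound 3 is expected to be longer-lived than compound 2, by a 9.8-fold higher number from compound 2 to compound 3 (0.99 log units; beyond the scatter). The estimate for compound 3 in this assay is 0.9 h, with a range from 0.25 h to 3 h.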

Compound 3, half-life: > 1.55 h
Compound 3: only a limit was reported; the forecaster's own chance of this, stated with the estimate: 30%; at least 1.7-fold (0.23 log units) between middle value and limit.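

In this assay, benzamido in place of ((thiophen-2-yl)carbonyl)oxy gives an at least 16-fold higher number from compound 2 to compound 3 (1.22 log units; beyond the scatter), so the short half-life of compound 2 is not shared by this second amido compound. Compound 3 gives > 1.55 h, which is a limit of the assay and not a number. An aromatic ring on the carbonyl therefore does not by itself go with a short half-life at this saturated ring carbon, since compound 3 carries a phenyl ring there and still reaches the same limit as compound 1, and the step from compound 1 to compound 3 cannot be read: the limit of > 1.55 h in this assay, at which 2 of the 3 values shown sit.

From the compounds shown here alone, the change from compound 2 to compound 3 alters both the attachment and the aromatic ring, so the share of each in the step stays open; the thiophene-2-carboxamide and the benzoate ester at this place would separate the two. Going by these compounds, how far compound 1 and compound 3 lie past their shared limit also stays open, as does whether a urea or a sulfonamide on the same saturated ring carbon would behave like the amido groups.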